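The compounds below may be only part of what the source reports. "The series", "measured", "known", "first", "only" and "open" are said of these compounds alone.

Within the data shown here, in a functional assay on MCF7 cells (Homo sapiens) for inhibition, with a stated time of 96 h (a lower number here means a stronger inhibitor, a higher number a weaker inhibitor), compound 2 `COc1cc(C(=O)c2cn(-c3ccc(C)cc3)cc2-c2ccco2)cc(OC)c1OC` gives 22 nM, the higher of the two numbers so far, and compound 1 `COc1cc(C(=O)c2cn(-c3ccc(C)cc3)cc2-c2ccsc2)cc(OC)c1OC` gives 4 nM. Compound 3 `COc1cc(C(=O)c2cn(-c3ccc(C)cc3)cc2-c2ccoc2)cc(OC)c1OC` differs from compound 2 in one group, with furan-3-yl in place of furan-2-yl on an aromatic carbon. Among the measured compounds shown here, the only measured step that bears on this is a 5.5-fold higher number from compound 1 to compound 2 (0.74 log units; beyond the scatter), a modest change beyond the scatter, and no measurement isolates the furan swap. The furan-3-yl name echoes the thiophen-3-yl of compound 1 at 4 nM, so a smaller move toward a lower number is expected, a 2.2-fold lower number from compound 2 to compound 3 (0.34 log units; beyond the scatter). Compound 3 is estimated at 10 nM, with an expected range of 3 nM to 30 nM.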

Compound 3, half-maximal inhibitory concentration: 18 nM
Compound 3: middle estimate off by 1.8-fold (0.26 log units), on the low side, within the range that was stated.
By their numbers in this assay, from the lowest: compound 1; then compounds 3 and 2 (each within the scatter of the next).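

Which carbon of the furan carries the bond hardly matters in this assay: the step is a 1.2-fold lower number from compound 2 to compound 3 (0.09 log units; within the scatter), so the two furans cannot be ordered. With the ring attached the same way, replacing thiophen-3-yl with furan-3-yl gives a 4.5-fold higher number from compound 1 to compound 3 (0.65 log units; beyond the scatter), so the earlier gap between compound 1 and compound 2 does not depend on the furan's attachment point. Nothing available explains either result. Still open, on these data alone, is whether thiophen-2-yl would match thiophen-3-yl. Also open, as far as these compounds go, is how a phenyl ring or an amine would fare on this aromatic carbon.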